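This account rests on a few compounds, and the source may have more. Where it says the series, first, only, none or still open, it means among the compounds named here.

Compound 2 `CC(CC(=O)O)N1Cc2ccc(NC(=O)c3ccc4c(c3)CNCC4)cc2C1=O` is the stronger of the two measured compounds in a functional assay on a cell-free system (Platelet, plasma, Homo sapiens) for inhibition; a higher number here means a weaker inhibitor, a lower number a stronger inhibitor: in that assay compound 2 gives 86 nM, the lowest of the two numbers. Its nearest neighbour is compound 1 `O=C(O)CN1Cc2ccc(NC(=O)c3ccc4c(c3)CNCC4)cc2C1=O`, which in this assay gives 120000 nM. Among the measured compounds shown here, the single measured step between them, a 1400-fold lower number from compound 1 to compound 2 (3.14 log units; beyond the scatter), is the only comparison in hand, and it shows that the group on the amide-type nitrogen in the ring has a large effect on the read-out.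

Compound 3 `O=C(O)CCCN1Cc2ccc(NC(=O)c3ccc4c(c3)CNCC4)cc2C1=O` differs from compound 2 in that same place: 3-carboxypropyl in place of 1-(carboxymethyl)ethyl on an amide-type nitrogen in a ring. The two have the same atoms, joined differently, and both keep one hydrogen-bond donor and one hydrogen-bond acceptor in the group that changes. For the measured compounds named here, no measured step bears directly on this rearrangement; the step from compound 1 to compound 2 concerned a different exchange of groups, so it cannot be carried over as a size.

Compound 3 is therefore expected to stay close to compound 2, with an estimated step of a 2.3-fold higher number from compound 2 to compound 3 (0.37 log units; beyond the scatter) in this assay, the estimate for compound 3 being 200 nM with a range from 50 nM to 1000 nM.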

Compound 3, half-maximal inhibitory concentration: 330000 nM
Beside the measured number, compound 3's estimate is 1700-fold (3.22 log units) below it; measured number above the stated range.
By their numbers in this assay, from the lowest: compound 2; then compound 1; then compound 3.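

The result shows that the position is sensitive to how the chain is joined and not only to which atoms it contains: in this assay the rearrangement gives a 3800-fold higher number from compound 2 to compound 3 (3.58 log units; beyond the scatter), even though the leaving and entering groups have the same atoms and the same counts of hydrogen-bond donors and acceptors. The unbranched 3-carboxypropyl group also gains nothing over carboxymethyl, with a 2.8-fold higher number from compound 1 to compound 3 (0.44 log units; beyond the scatter), so a longer unbranched chain does not by itself account for the low number of compound 2. Among these three compounds, only compound 2 with its branched 1-(carboxymethyl)ethyl group gives a low number, while compound 1 and compound 3 both stay far weaker. Nothing available here accounts for this sharp difference between the two arrangements.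

The compounds shown leave open whether the branching itself matters or the particular spacing of the carboxylic acid from the ring nitrogen, which a 2-carboxyethyl or a 1-carboxyethyl group would help to separate. They also leave open whether the carboxylic acid is needed at all, for example whether a methyl ester or an amide could stand in its place on the branched chain.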